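This account rests on a few compounds, and the source may have more. Where it says the series, first, only, none or still open, it means among the compounds named here.

Compound 1, `Cc1cccc2cc([C@H](C)Nc3ncnc4[nH]cnc34)c(-c3ccccc3)c(=O)n12`, gives 70% in an ADME assay on microsomes from liver (Homo sapiens), read by LC-MS, using NADPH, with a stated time of 30 min, tested at 1 uM; a lower number here means that less of the compound is left, a higher number that more of the compound is left.
Compound 2, `C[C@H](Nc1nc(N)nc(N)c1C#N)c1cc2ccc(F)cn2c(=O)c1-c1ccccc1`, gives 87% in this assay.
Compound 3, `Cc1c([C@H](C)Nc2nc(N)nc(N)c2C#N)c(-c2ccccc2)c(=O)n2cc(F)ccc12`, gives 80% in this assay.

On these three numbers compound 3 stands second highest. Its nearest neighbour is compound 2, and the gap between them lies within the usual scatter of repeated measurements; the gap to compound 1 lies within that scatter as well, so the three compounds cannot be told apart on this read-out.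

Compound 4, `C[C@H](Nc1nc(N)nc(N)c1C#N)c1c(-c2ccccc2)c(=O)n2cc(F)ccc2c1C1CC1`, has not been measured. It differs from compound 3 in one place: cyclopropyl in place of methyl on an aromatic carbon. The spot in question sits on an aromatic carbon of a six-membered aromatic ring, ortho to a fused ring and ortho to a large group, within the shared core.

Within the data shown here, only one measured step touches that same carbon, a methyl in place of hydrogen, and it was small: a number 7 percentage points lower from compound 2 to compound 3 (within the scatter). Among the measured compounds shown here, whether the larger cyclopropyl behaves like the methyl cannot be read from these compounds, but the single step available shows no movement beyond the scatter, so no step beyond the scatter is expected in this assay here either. Compound 4 is therefore expected to give about 75%, with a likely range from 55% to 92%. This estimate corresponds to an expected step of a number 5 percentage points lower from compound 3 to compound 4 (within the scatter).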

Compound 4, percent of the compound remaining: 91%
Estimate against measurement, compound 4: 16 percentage points below; low and high end bracket the measured number.
By their numbers in this assay, from the lowest: compounds 1, 3, 2 and 4 (each within the scatter of the next, the first and the last beyond it).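

In this assay, this position now shows a step beyond the usual scatter: cyclopropyl in place of methyl on this aromatic carbon gives a number 11 percentage points higher from compound 3 to compound 4 (beyond the scatter), a modest step, so the group held here can matter for how much compound is left. Measured against hydrogen, cyclopropyl gives a number 4 percentage points higher from compound 2 to compound 4 (within the scatter) and methyl gives a number 7 percentage points lower from compound 2 to compound 3 (within the scatter), so neither group can be told apart from hydrogen on this read-out, and only the two groups compared directly with each other are separated. Nothing at hand explains the step between methyl and cyclopropyl.

From the compounds shown here alone, what stays open is how other groups on this same carbon would fall relative to these three: an ethyl or an isopropyl group would show how the number follows a larger carbon group without a ring, and an amine or a methoxy group would show what happens when the carbon group gives way to one holding nitrogen or oxygen. The step also rests on one pair of compounds, so it cannot be said whether it would carry over to a different core.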